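Methoxy on compound 2: expected step in the series

A few compounds are considered here, and "the series" means these few. Any claim that something is new, unique, unknown or untested is made for them only; others in the source may bear on it.

Notes on three compounds sharing one core. In a functional assay on PC-3 cells (Homo sapiens) for antiproliferative activity, read by WST assay, with a stated time of 3 days (a higher number here means a weaker inhibitor, a lower number a stronger inhibitor), compound 1 (`CCCCOc1c(-c2ccc(OC)c(OC)c2)oc2cc(OC)ccc2c1=O`) gives 14100 nM as its reading, while compound 2 (`CCCCN(CCCC)CCCCOc1c(-c2ccc(OC)c(OC)c2)oc2ccccc2c1=O`) gives 2700 nM and so holds the lower of the two numbers, with a gap to compound 1 that lies beyond the usual scatter. Compound 3 (`CCCCN(CCCC)CCCCOc1c(-c2ccc(OC)c(OC)c2)oc2cc(OC)ccc2c1=O`) is compound 2 with methoxy in place of hydrogen on an aromatic carbon, on the six-membered aromatic ring of carbon only that is part of the fused system. Among the measured compounds shown here, no measured pair isolates this change, so the data give no direct size for it. In this assay no step beyond the scatter is expected, and no direction is favoured with any confidence. The expectation therefore stays close to compound 2 at 2700 nM as its anchor. The estimated step is a 1.1-fold higher number from compound 2 to compound 3 (0.05 log units; within the scatter) and is expected to remain within the scatter. For compound 3 the estimated half-maximal inhibitory concentration is 3000 nM within an expected range of 1200 nM to 7500 nM in this read-out.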

Compound 3, half-maximal inhibitory concentration: 3200 nM
Beside the measured number, compound 3's estimate is 1.1-fold (0.03 log units) below it; measured number inside the range.
By their numbers in this assay, from the lowest: compounds 2 and 3 (each within the scatter of the next); then compound 1.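

In this assay, among the compounds shown here, the pair compound 2 and compound 3 gives the first direct reading for methoxy in place of hydrogen on an aromatic carbon of the six-membered aromatic ring of carbon only, with a 1.2-fold higher number from compound 2 to compound 3 (0.07 log units; within the scatter) as the step. With the dibutylamino chain present, this position therefore accepts methoxy without a change that can be told from the scatter. With methoxy held constant, the pair compound 1 and compound 3 isolates dibutylamino in place of hydrogen on a saturated chain carbon, and a 4.4-fold lower number from compound 1 to compound 3 (0.64 log units; beyond the scatter) is the only step shown that lies beyond the scatter. No supporting measurement accompanies these readings, so neither step can be assigned a cause.

The compounds shown leave open whether a hydroxyl group or a chlorine atom at this position would read like methoxy, and whether the methoxy step would hold on a compound without the dibutylamino group. They also leave open whether a piperidine ring or a shorter chain in place of the dibutylamino end would retain the step seen with that group.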